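From Thiazole Amide to Chloropyridine Amide in Rat Blood

This account rests on a few compounds, and the source may have more. Where it says the series, first, only, none or still open, it means among the compounds named here.

Three compounds share one core and differ only in the group on the amide carbonyl carbon. Compound 1 `CC(=O)NCCC1CCN(S(=O)(=O)NC(=O)NC[C@@H]2C[C@@H]3C=C[C@@H]2C3)CC1` carries a methyl there, and in a functional assay on the whole organism (blood) with Rattus norvegicus as the target, with stated times of 24 h and 1 h, at a dose of 15 mg/kg by the intraperitoneal route (on this read-out higher numbers stand for a stronger effect at the one dose given and lower numbers for a weaker effect), compound 1 gives 25%. Compound 2 `Cc1ncsc1C(=O)NCCC1CCN(S(=O)(=O)NC(=O)NC[C@@H]2C[C@@H]3C=C[C@@H]2C3)CC1` carries a 4-methyl-1,3-thiazol-5-yl, and in this assay compound 2 gives 25%; the step of no change at the digits printed from compound 1 to compound 2 (within the scatter). Compound 3 `O=C(NC[C@@H]1C[C@@H]2C=C[C@@H]1C2)NS(=O)(=O)N1CCC(CCNC(=O)c2cscn2)CC1` carries a 1,3-thiazol-4-yl, and in this assay compound 3 gives 37%, the highest of the three numbers, with a number 12 percentage points higher from compound 1 to compound 3 (beyond the scatter) and a number 12 percentage points higher from compound 2 to compound 3 (beyond the scatter) both beyond the scatter.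

Compound 4 `O=C(NC[C@@H]1C[C@@H]2C=C[C@@H]1C2)NS(=O)(=O)N1CCC(CCNC(=O)c2cnccc2Cl)CC1` changes the same position once more: 4-chloropyridin-3-yl in place of 1,3-thiazol-4-yl on a carbonyl carbon. Among the compounds with values here, the steps that bear on this are the two into compound 3, each modest, and the flat step from compound 1 to compound 2. Across these three groups on the carbonyl carbon the read-out moved within a narrow band, with only the 1,3-thiazol-4-yl rising above it. Because compound 1 gives 25% and compound 2 gives 25%, compound 4 is expected to fall back toward that band, giving an estimated step of a number 8 percentage points lower from compound 3 to compound 4 (within the scatter). For compound 4 the estimate in this assay is 29%, within a range of 17% to 42%.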

Compound 4, a percentage reported as activity, at one dose (the size of the read-out at that dose, not a potency): 12%
Estimate against measurement, compound 4: 17 percentage points above, outside the stated range (below it).
By their numbers in this assay, from the lowest: compound 4; then compounds 1 and 2 (each within the scatter of the next); then compound 3.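

Within the data shown here, the result shows that this position can lower the read-out as well as raise it: in this assay, the change to 4-chloropyridin-3-yl gives a number 25 percentage points lower from compound 3 to compound 4 (beyond the scatter), so the earlier compounds' narrow band was no floor. The fall also carries past the simpler groups, with a number 13 percentage points lower from compound 1 to compound 4 (beyond the scatter) and a number 13 percentage points lower from compound 2 to compound 4 (beyond the scatter), which leaves compound 4 the weakest of the four at this dose and shows that an aromatic ring on the carbonyl carbon does not by itself set the direction, as compound 3 stands above the methyl compound and compound 4 below it. No measurement shown here bears on why the read-out fell.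

This change replaces the five-membered ring with a six-membered one and brings in chlorine at the same time, so the compounds shown cannot say which of the two goes with the lower number; a pyridin-3-yl without the chlorine would separate them. From the compounds shown here alone, how a group of another kind on this carbonyl carbon, such as a chain ending in an amine or a carboxylic acid, would read in this assay also remains open.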